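A few compounds are considered here, and "the series" means these few. Any claim that something is new, unique, unknown or untested is made for them only; others in the source may bear on it.

Working notes on the series. The shared core is that of compound 1 `COc1cc(-c2cc(/C=C/C(=O)c3ccc(N)cc3)[nH]n2)cc(OC)c1OC`; in a functional assay on MDA-MB-231 cells (Homo sapiens) for inhibition, read by MTT assay, with a stated time of 48 h (a lower number here means a stronger inhibitor, a higher number a weaker inhibitor), compound 1 gives 2000 nM. Compound 2 `COc1cc(-c2cc(/C=C/C(C)=O)[nH]n2)cc(OC)c1OC` carries a methyl in place of the 4-aminophenyl on the carbonyl carbon, and in this assay compound 2 gives 27300 nM. Among the measured compounds shown here, the only measured step, a 14-fold higher number from compound 1 to compound 2 (1.14 log units; beyond the scatter), is large and beyond the scatter, so compound 2 stands with the higher of the two numbers, its sole neighbour being compound 1.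

Compound 3 `COc1ccc(C(=O)/C=C/c2cc(-c3cc(OC)c(OC)c(OC)c3)n[nH]2)cc1` differs from compound 2 by 4-methoxyphenyl in place of methyl on a carbonyl carbon. For the measured compounds named here, the one step that bears on this change is a 14-fold higher number from compound 1 to compound 2 (1.14 log units; beyond the scatter), which went the other way: removing a six-membered aromatic ring from the carbonyl carbon in favour of methyl raised the number strongly. Going by the values given here, the present change puts an aromatic ring back on that carbon, though with a methoxy rather than an amino substituent, and no measured pair compares those two groups. The expectation is therefore a large drop of roughly the size of the reverse of the measured step, a 9.1-fold lower number from compound 2 to compound 3 (0.96 log units; beyond the scatter), with added uncertainty for the different substituent. Compound 3 is estimated at 3000 nM in this assay, with a range of 900 nM to 12000 nM.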

Compound 3, half-maximal inhibitory concentration: 950 nM
The estimate for compound 3 lay 3.2-fold (0.50 log units) above the measured number, within the range that was stated.
By their numbers in this assay, from the lowest: compound 3; then compound 1; then compound 2.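

With two aromatic groups now on the carbonyl carbon, the position reads more firmly: 4-methoxyphenyl in place of methyl gives a 29-fold lower number from compound 2 to compound 3 (1.46 log units; beyond the scatter) in this assay, so the large gap seen with 4-aminophenyl is not confined to that one group. Among the compounds shown here, the substituent on the aromatic ring also counts, though for less, since methoxy in place of amino on an aromatic carbon gives a 2.1-fold lower number from compound 1 to compound 3 (0.32 log units; beyond the scatter), a modest step but beyond the scatter, and this is the first direct comparison of the two aromatic groups. No supporting data bear on why either step takes the size it does.

The compounds shown leave open whether the aromatic ring itself matters or whether the larger group on the carbonyl carbon would serve equally well, a question that unsubstituted phenyl, cyclohexyl or a longer chain such as n-butyl would address. They also leave open how far the trend in the ring substituent runs, for instance with a hydroxyl, a fluorine or a carboxylic acid in place of the methoxy.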